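Methyl to cyano step carried onto the imidazolyl core

The source may report more compounds than this note shows. Statements on the series, on what has been measured and on what is new or still open speak of the compounds shown alone.

In a functional assay on MDA-MB-231 cells (Homo sapiens) for inhibition, read by sulforhodamine B assay, tested at 10 uM (on this read-out higher numbers stand for more inhibition at the one concentration tested (going by the name of the read-out) and lower numbers for less inhibition), compound 1 `Cc1ccc(S(=O)(=O)N2N=C(c3ccc(-n4cncn4)cc3)CC2c2ccc(N(C)C)cc2)cc1` gives 20.7%. In this assay compound 2 `CN(C)c1ccc(C2CC(c3ccc(-n4cncn4)cc3)=NN2S(=O)(=O)c2ccc(C#N)cc2)cc1` gives 32.8%; the change is cyano in place of methyl on an aromatic carbon, and the step is a number 12.1 percentage points higher from compound 1 to compound 2 (beyond the scatter). In this assay compound 3 `Cc1ccc(S(=O)(=O)N2N=C(c3ccc(-n4ccnc4)cc3)CC2c2ccc(N(C)C)cc2)cc1` gives 50.8%. The core of compound 3 differs from the core of compound 1 by 1H-imidazol-1-yl in place of 1H-1,2,4-triazol-1-yl on an aromatic carbon, and that step is a number 30.1 percentage points higher from compound 1 to compound 3 (beyond the scatter). Among the three measured compounds, compound 3 stands highest, with compound 2 nearest and compound 1 furthest, both gaps beyond the scatter.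

Compound 4 `CN(C)c1ccc(C2CC(c3ccc(-n4ccnc4)cc3)=NN2S(=O)(=O)c2ccc(C#N)cc2)cc1` is not yet measured in this assay. It differs from compound 3 by cyano in place of methyl on an aromatic carbon, the same change, at the same place, as from compound 1 to compound 2, now made on the core of compound 3. The step from compound 3 to compound 4 is expected to be about a number 12.2 percentage points higher from compound 3 to compound 4 (beyond the scatter), set beside the earlier step of a number 12.1 percentage points higher from compound 1 to compound 2 (beyond the scatter); that expectation rests on this one measured pair only, so the range is kept wide. Compound 4 is estimated at 63%, between 46% and 78%.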

Compound 4, a percentage reported as inhibition, at one concentration (the size of the read-out at that concentration, not a potency): 7.1%
For compound 4 the middle estimate is 55.9 percentage points above the measured one; measured number outside the range, below it.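

In this assay, cyano in place of methyl with the 1H-imidazol-1-yl group present gives a number 43.7 percentage points lower from compound 3 to compound 4 (beyond the scatter), so the step changes direction and does not carry over from the 1H-1,2,4-triazol-1-yl pair: the same change on two cores in this assay, a number 12.1 percentage points higher (beyond the scatter) from compound 1 to compound 2 and a number 43.7 percentage points lower (beyond the scatter) from compound 3 to compound 4, 55.8 percentage points apart, beyond the scatter of two such steps

With the 4-cyanophenyl sulfonyl group present, 1H-imidazol-1-yl in place of 1H-1,2,4-triazol-1-yl gives a number 25.7 percentage points lower from compound 2 to compound 4 (beyond the scatter), so that change reverses as well: the same change on two cores in this assay, a number 30.1 percentage points higher (beyond the scatter) from compound 1 to compound 3 and a number 25.7 percentage points lower (beyond the scatter) from compound 2 to compound 4, 55.8 percentage points apart, beyond the scatter of two such steps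

Across these four compounds the two changes do not add, and neither step can be transferred on its own, but this single set of four readings at one concentration shows neither why they interact nor whether the same holds for other changes in the series.

The compounds shown leave open whether a chlorine atom, a methoxy group or a carboxylic acid at the place of the methyl would follow the methyl or the cyano result on each core. Also open, on these data alone, is whether a 1H-pyrazol-1-yl group in place of the 1H-imidazol-1-yl group would give the same reversal.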